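The source may report more compounds than this note shows. Statements on the series, on what has been measured and on what is new or still open speak of the compounds shown alone.

Going by the values given here, in an ADME assay on RAW264.7 cells (Mus musculus) for cytotoxicity, read by MTT assay, with a stated time of 48 h (on this read-out lower numbers stand for higher toxicity in this test and higher numbers for lower toxicity in this test), compound 1 `COc1ccc(NC(=S)N/N=C\c2ccnc3ccccc23)cc1` gives 101000 nM and compound 2 `S=C(N/N=C\c1ccnc2ccccc12)Nc1cccnc1` gives 91600 nM, so compound 2 stands level with the only other number, within the scatter. Compound 3 `CCc1ccc(NC(=S)N/N=C\c2ccnc3ccccc23)cc1` differs from compound 2 by one change, 4-ethylphenyl in place of pyridin-3-yl on an amide-type nitrogen. Among the compounds with values here, one measured step bears on this place, a 1.1-fold lower number from compound 1 to compound 2 (0.04 log units; within the scatter), and it stayed within the scatter. No step beyond the scatter is therefore expected in this assay. The expected step is a 1.0-fold higher number from compound 2 to compound 3 (0.02 log units; within the scatter). Compound 3 is estimated at 95000 nM, with an expected range of 40000 nM to 200000 nM.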

Compound 3, half-maximal cytotoxic concentration: 35700 nM
For compound 3 the middle estimate is 2.7-fold (0.43 log units) above the measured one; measured number below the stated range.
By their numbers in this assay, from the lowest: compound 3; then compounds 2 and 1 (each within the scatter of the next).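

In this assay the group on the amide-type nitrogen turns out to matter: 4-ethylphenyl in place of pyridin-3-yl gives a 2.6-fold lower number from compound 2 to compound 3 (0.41 log units; beyond the scatter), where the earlier pair had stayed level. Ethyl in place of methoxy on an aromatic carbon gives a 2.8-fold lower number from compound 1 to compound 3 (0.45 log units; beyond the scatter), so a change of one small group is enough to shift the number, towards higher toxicity in this test. Nothing available here accounts for this shift. Still open, on these data alone, is whether a longer chain such as propyl would go further than ethyl, and how an amine or a carboxylic acid in its place would compare.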